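Urea aryl variation on the shared core

The source may report more compounds than this note shows. Statements on the series, on what has been measured and on what is new or still open speak of the compounds shown alone.

Compound 1 `COc1ccc(NC(=O)Nc2cccc(-c3nc(-c4ccc(NC(=O)c5cccnc5)cc4Cl)no3)c2)cc1C(F)(F)F`: in a functional assay on MDA-MB-231 cells (Homo sapiens) for antiproliferative activity, read by MTT assay, with a stated time of 72 h (a lower number here means a stronger inhibitor, a higher number a weaker inhibitor), compound 1 gives 1700 nM.
Compound 2 `CS(=O)(=O)Nc1cccc(NC(=O)Nc2cccc(-c3nc(-c4ccc(NC(=O)c5cccnc5)cc4Cl)no3)c2)c1`: in this assay compound 2 gives > 10000 nM, a limit of the assay and not a number.

Compound 2 sits at the limit of > 10000 nM in this assay, at which 1 of the 2 values shown sits. Going by the values given here, the only measured step, an at least 5.8-fold higher number from compound 1 to compound 2 (0.76 log units; beyond the scatter), exchanges the whole aryl group on the urea and does not test the position of the methanesulfonamide. Compound 3 `CS(=O)(=O)Nc1ccc(NC(=O)Nc2cccc(-c3nc(-c4ccc(NC(=O)c5cccnc5)cc4Cl)no3)c2)cc1` differs from compound 2 by 4-(methanesulfonamido)phenyl in place of 3-(methanesulfonamido)phenyl on an amide-type nitrogen. Among the compounds with values here, with no measured step bearing on this positional change, compound 3 is expected to remain weak, with a number no higher from compound 2 to compound 3 (the limit leaves the size open) as the estimated step. Compound 3 is estimated at 10000 nM in this assay, within 3000 nM to 30000 nM.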

Compound 3, half-maximal inhibitory concentration: 600 nM
Compound 3: middle estimate off by 17-fold (1.22 log units), on the high side; measured number outside the range, below it.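

The position of the methanesulfonamide on the urea aryl group decides the outcome in this assay: 4-(methanesulfonamido)phenyl in place of 3-(methanesulfonamido)phenyl gives an at least 16-fold lower number from compound 2 to compound 3 (1.22 log units; beyond the scatter), with the same atoms joined differently. The value of compound 2 is a limit of the assay and not a number: the limit of > 10000 nM in this assay, at which 1 of the 3 values shown sits. The 4-(methanesulfonamido)phenyl group also improves on the aryl group of compound 1, with a 2.8-fold lower number from compound 1 to compound 3 (0.45 log units; beyond the scatter).

Whether the methanesulfonamide itself is needed remains open, as no other group is shown on this aryl ring in the same place. An amine, a carboxylic acid or a longer chain in its stead would test this.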